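The source may report more compounds than this note shows. Statements on the series, on what has been measured and on what is new or still open speak of the compounds shown alone.

Compound 1 `Cc1nn(-c2ncnc3nc[nH]c23)c2c1C(OCc1ccc(Cl)cc1Cl)CC(=O)N2` is the starting point of this step. Among the measured compounds shown here, in a functional assay on HEK293 cells for agonist activity at G-protein coupled receptor 39 (Homo sapiens), read by scintillation proximity assay and inositol phosphate accumulation, with a stated time of 75 min, in the presence of a further agent that is not named here (a lower number here means that less compound is needed, a higher number that more compound is needed for the effect), compound 1 gives 4 nM, the second highest of the three numbers measured so far. Compound 2 `Cc1nn(-c2ncnc3nc[nH]c23)c2c1C(NC(=O)Cc1cccs1)CC(=O)N2` gives 3 nM in this assay, and compound 3 `Cc1nn(-c2ncnc3nc[nH]c23)c2c1C(OCCn1cccn1)CC(=O)N2` gives 16 nM. Among the measured steps, a 1.3-fold lower number from compound 1 to compound 2 (0.12 log units; within the scatter), whereas a 4.0-fold higher number from compound 1 to compound 3 (0.60 log units; beyond the scatter) and a 5.3-fold higher number from compound 2 to compound 3 (0.73 log units; beyond the scatter). Compound 4 `Cc1nn(-c2ncnc3nc[nH]c23)c2c1C(OCc1ccccc1Cl)CC(=O)N2` is not yet measured. It differs from compound 1 as follows: hydrogen in place of chloro on an aromatic carbon. For the measured compounds named here, no measured step removes one chloro from the 2,4-dichlorophenyl on its own. The step from compound 1 to compound 3 exchanges the whole 2,4-dichlorophenyl for (1H-pyrazol-1-yl)methyl and is a loose guide at best, and the step from compound 1 to compound 2 replaces the entire (2,4-dichlorobenzyl)oxy group. The change in compound 4 is smaller than either, so the expected step of a 2.0-fold higher number from compound 1 to compound 4 (0.30 log units; within the scatter) is estimated to be small, toward a higher number, and may well stay within the scatter. Compound 4 is expected to give 8 nM, with a range from 3 nM to 25 nM.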

Compound 4, half-maximal effective concentration: 2 nM
Compound 4: middle estimate off by 4.0-fold (0.60 log units), on the high side, outside the stated range (below it).
By their numbers in this assay, from the lowest: compounds 4, 2 and 1 (each within the scatter of the next); then compound 3.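

In this assay, removing only the chloro para to a large group, which turns (2,4-dichlorobenzyl)oxy into (2-chlorobenzyl)oxy, stays within the scatter (a 2.0-fold lower number from compound 1 to compound 4 (0.30 log units; within the scatter)), so this chloro is not required for activity in the series as shown. The (2-chlorobenzyl)oxy group and the (((thiophen-2-yl)methyl)carbonyl)amino group also cannot be separated (a 1.5-fold lower number from compound 2 to compound 4 (0.18 log units; within the scatter)), whereas the 2-(1H-pyrazol-1-yl)ethoxy compound remains clearly apart from the monochloro ether (an 8.0-fold lower number from compound 3 to compound 4 (0.90 log units; beyond the scatter)). No available evidence bears on the origin of these results.

As far as these compounds go, it remains open whether the remaining chloro can also give way to hydrogen, or be exchanged for a methoxy group or a carboxylic acid. From the compounds shown here alone, the effect of a longer chain between the ether oxygen and the aromatic ring is also open.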